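This account rests on a few compounds, and the source may have more. Where it says the series, first, only, none or still open, it means among the compounds named here.

Compound 1, `Cc1cc(NC(=O)Nc2cc(F)ccc2F)c2ccccc2n1`: in an ADME assay on HepG2 cells (Homo sapiens) for cytotoxicity, with a stated time of 72 h (a lower number here means that less compound is needed, a higher number that more compound is needed for the effect), compound 1 gives > 25000 nM, a limit of the assay rather than a number.
Compound 2, `Cc1cc(NC(=O)Nc2ccccc2F)c2ccccc2n1`: compound 2 gives > 25000 nM, again a limit of the assay.
Compound 3, `Cc1cc(NC(=O)Nc2ccc(F)cc2F)c2ccccc2n1`: compound 3 gives 17000 nM.

Compound 2 therefore stands at the same limit as compound 1, the limit described by the limit of > 25000 nM in this assay, at which 2 of the 3 values shown sit. Because compound 2 sits at that limit, its true value is not known, only that it lies beyond the reach of this assay.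

The step from compound 2 to compound 4, `Cc1cc(NC(=O)Nc2ccccc2N)c2ccccc2n1`, is amino in place of fluoro on an aromatic carbon. Within the data shown here, none of the measured steps tries this same change. The two that exist are a step that the two limits leave unreadable from compound 1 to compound 2 and an at least 1.4-fold lower number from compound 2 to compound 3 (0.16 log units; that floor lies within the scatter). The first cannot be read at all, since both of its values are limits; the second is a small shift whose floor lies within the scatter. Taken together they show only that fluoro moved or removed on this ring has not produced a change that stands out from the scatter. For compound 4 the expectation is therefore a step of roughly a number no higher from compound 2 to compound 4 (the limit leaves the size open), meaning no movement beyond the scatter, with a real chance that compound 4 again gives only a limit. Compound 4 is estimated at 25000 nM, within 9000 nM to 60000 nM.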

Compound 4, half-maximal effective concentration: > 25000 nM
Compound 4 gave a limit, no number; the forecaster's own chance of this, stated with the estimate: 55%; the middle value lies on the limit itself.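

Compound 2 and compound 4 both stop at the same limit rather than giving a number, so no size can be read for the change from fluoro to amino: the limit of > 25000 nM in this assay, at which 3 of the 4 values shown sit.
The compounds shown leave open whether amino in place of fluoro shifts the true value in this assay at all, and in which direction.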